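The source may hold more compounds than are shown below. What is called first, only, known or untested is meant among the compounds shown, and "the series" means these compounds.

In a functional assay on U-87MG ATCC cells for antiproliferative activity against U-87 MG (Homo sapiens), read by MTT assay, with a stated time of 48 h (a higher number here means a weaker inhibitor, a lower number a stronger inhibitor), compound 3 `COc1ccc(-c2nc(SCC(=O)c3sc(-c4ccccc4)nc3C)[nH]c(=O)c2C#N)cc1OC` gives 15300 nM and so lies within the usual scatter of compound 1 `COc1ccc(-c2nc(C)c(C(=O)CSc3nc(-c4ccc(OC)c(OC)c4)c(C#N)c(=O)[nH]3)s2)cc1` at 12500 nM on the same scale. Compound 2 `Cc1nc(-c2ccc(Cl)cc2)sc1C(=O)CSc1nc(-c2cccc(Cl)c2)c(C#N)c(=O)[nH]1` at 40100 nM stands apart from both, beyond the scatter, with a higher number that marks a weaker inhibitor.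

Compound 4 `COc1ccc(-c2nc(SCC(=O)c3sc(-c4ccc(Cl)cc4)nc3C)[nH]c(=O)c2C#N)cc1OC` differs from compound 3 in one place, phenyl to 4-chlorophenyl: chloro in place of hydrogen on an aromatic carbon is the count for this swap, chloro in place of hydrogen on an aromatic carbon, para to a large group.

One measured step offers a comparison, since it also changes a single small group on an aromatic carbon. That step, a 1.2-fold higher number from compound 1 to compound 3 (0.09 log units; within the scatter) with hydrogen in place of methoxy, shows that such a swap can leave the number unmoved. Compound 2 also carries 4-chlorophenyl, and its 40100 nM hints weakly at a higher number, yet it differs elsewhere too, so it cannot isolate the chloro. Among the compounds with values here, no measured pair tests the chloro alone.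

The expected change in this assay is therefore small, an estimated 1.2-fold higher number from compound 3 to compound 4 (0.09 log units; within the scatter) that leans slightly upward but stays within the scatter. Compound 4 is expected to read 19000 nM with 9000 nM to 40000 nM as its estimated range.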

Compound 4, half-maximal inhibitory concentration: 38600 nM
For compound 4 the middle estimate is 2.0-fold (0.31 log units) below the measured one; measured number inside the range.
By their numbers in this assay, from the lowest: compounds 1 and 3 (each within the scatter of the next); then compounds 4 and 2 (each within the scatter of the next).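

In this assay, putting a chloro group on the phenyl ring, para to a large group, is not a neutral change: the result is a 2.5-fold higher number from compound 3 to compound 4 (0.40 log units; beyond the scatter), a weaker inhibitor, whereas the earlier swap at this position gave only a 1.2-fold higher number from compound 1 to compound 3 (0.09 log units; within the scatter). The direct exchange of the two substituents at this position gives a 3.1-fold higher number from compound 1 to compound 4 (0.49 log units; beyond the scatter), so among these three compounds hydrogen and methoxy read alike, and only chloro stands apart. Once the 4-chlorophenyl is in place, the change elsewhere in the molecule from 3-chlorophenyl to 3,4-dimethoxyphenyl gives a 1.0-fold lower number from compound 2 to compound 4 (0.02 log units; within the scatter), so that exchange leaves the number unmoved in this pair.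

No measurement in hand explains why the chloro group shifts the number in this way. On these data alone, it also remains open whether a fluoro group, a methyl group, an amine or a carboxylic acid in this same place would read like hydrogen and methoxy or like chloro, and whether the chloro effect would hold on another member of the series.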